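Fluoro for benzoyl on the aryl of compound 2

A few compounds are considered here, and "the series" means these few. Any claim that something is new, unique, unknown or untested is made for them only; others in the source may bear on it.

Three members of the series carry measured values. In an assay on PMNL cells for inhibition of Polyunsaturated fatty acid 5-lipoxygenase (Homo sapiens), read by HPLC, with stated times of 15 min and 10 min (a higher number here means a weaker inhibitor, a lower number a stronger inhibitor), compound 1 `O=C1N=C(c2ccc(Oc3ccccc3)cc2)S/C1=C\c1ccc(Oc2ccccc2)cc1` gives 90 nM. Compound 2 `COc1ccc(/C=C2\SC(c3ccc(C(=O)c4ccccc4)cc3)=NC2=O)cc1` gives 150 nM in this assay. Compound 3 `COc1ccc(/C=C2\SC(c3ccc(Oc4ccccc4)cc3)=NC2=O)c2ccccc12` gives 140 nM. Compound 2 has the highest number of the three, yet its gap to compound 3 and its gap to compound 1 both lie within the usual scatter, so no order among these three can be read from the numbers.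

Compound 4 `COc1ccc(/C=C2\SC(c3ccc(F)cc3)=NC2=O)cc1` is not yet measured. It differs from compound 2 in one place: fluoro in place of benzoyl on an aromatic carbon. Going by the values given here, no pair of measured compounds shows this change, so no measured step can guide the expectation. Each measured compound carries a large group where compound 4 carries only fluoro. Compound 4 is expected to show a step beyond the scatter toward a weaker inhibitor, a 3.3-fold higher number from compound 2 to compound 4 (0.52 log units; beyond the scatter). Compound 4 is estimated at 500 nM in this assay, with a range from 150 nM to 2000 nM.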

Compound 4, half-maximal inhibitory concentration: 550 nM
For compound 4 the middle estimate is 1.1-fold (0.04 log units) below the measured one; low and high end bracket the measured number.
By their numbers in this assay, from the lowest: compounds 1, 3 and 2 (each within the scatter of the next); then compound 4.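

In this assay, going by these compounds alone, fluoro in place of benzoyl gives a 3.7-fold higher number from compound 2 to compound 4 (0.56 log units; beyond the scatter), the only step so far and one beyond the scatter, which shows that this position, on an aromatic carbon para to a large group, does respond to a change of substituent. The change removes a six-membered aromatic ring and a carbonyl together, yet the inhibitor weakens only modestly and compound 4 still gives a value on the same nanomolar scale. Nothing available bears on the cause of this step.

The compounds shown do not separate the contribution of the ring from that of the carbonyl, since only benzoyl and fluoro are compared at this position on this core. From the compounds shown here alone, how a phenyl, a benzyl, an acetyl, an amine or a carboxylic acid would read here remains open.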